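The source may report more compounds than this note shows. Statements on the series, on what has been measured and on what is new or still open speak of the compounds shown alone.

Measured so far in an assay on tissue (RPTEC cells) for inhibition of solute carrier family 22 member 12 (Homo sapiens), read by scintillation counting, with stated times of 15 min and 2 h; a higher number here means a weaker inhibitor, a lower number a stronger inhibitor:
compound 1 `N#Cc1cc(C(=O)N2CCc3ccccc32)cc(Cl)c1O` gives 14700 nM
compound 2 `N#Cc1cc(C(=O)N2CCc3ccccc32)cc(C(F)(F)F)c1O` gives > 100000 nM, a limit of the assay
compound 3 `N#Cc1cc(C(=O)N2CS(=O)(=O)c3ccccc32)cc(C(F)(F)F)c1O` gives > 100000 nM, a limit of the assay

Compound 2 sits at the limit of this assay. Compound 3 sits at the same limit. Only compound 1 returns a number. For the measured compounds named here, the one measured step runs an at least 6.8-fold lower number from compound 2 to compound 1 (0.83 log units; beyond the scatter); the change behind it is chloro in place of trifluoromethyl on an aromatic carbon. The step is given only as a bound because of the limit of > 100000 nM in this assay, at which 2 of the 3 values shown sit.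

Compound 4 `N#Cc1cc(C(=O)N2CS(=O)(=O)c3ccccc32)cc(Cl)c1O` is not yet measured. It arises from compound 3 by chloro in place of trifluoromethyl on an aromatic carbon, the same change that separates compound 2 from compound 1, as the place lines match word for word. The difference between the two cores, that of compound 2 and that of compound 3, is not broken down here.

For compound 4 in this assay, the step from compound 3 is expected to be an at least 3.3-fold lower number from compound 3 to compound 4 (0.52 log units; beyond the scatter). This rests on the step from compound 2 to compound 1 alone, which in turn starts from a limit, so the size is uncertain in both directions; compound 3 also starts from a limit, so the number may again be only a bound. The estimate for compound 4 is 30000 nM, with a range from 8000 nM to 100000 nM.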

Compound 4, half-maximal inhibitory concentration: > 100000 nM
Compound 4: a limit, no number; the forecaster's own chance of this, stated with the estimate: 35%; middle value at least 3.3-fold (0.52 log units) from the limit.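

In this assay, compound 3 and compound 4 both sit at the limit of the assay, so no step between them can be read, because neither returns a number: the limit of > 100000 nM in this assay, at which 3 of the 4 values shown sit.

The compounds shown leave open whether chloro in place of trifluoromethyl on an aromatic carbon changes the read-out at all on the core of compound 3, as it does on the core of compound 2.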